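This account rests on a few compounds, and the source may have more. Where it says the series, first, only, none or still open, it means among the compounds named here.

Of the compounds shown here, three sharing one core have been measured in a physicochemical assay for solubility, in phosphate buffer, at pH 6.5; a higher number here means a more soluble compound, a lower number a less soluble compound. Compound 1 `C=C[C@@H]1C[C@]1(NC(=O)[C@@H]1C[C@@H](Oc2nccc3cc(OC)ccc23)CN1C(=O)[C@@H](NC(=O)N[C@@H](C)COC)C(C)(C)C)C(=O)NS(=O)(=O)C1CC1` gives 1070 ug/mL. Compound 2 `C=C[C@@H]1C[C@]1(NC(=O)[C@@H]1C[C@@H](Oc2nccc3cc(OC)ccc23)CN1C(=O)[C@@H](NC(=O)N[C@@H](CC)COC)C(C)(C)C)C(=O)NS(=O)(=O)C1CC1` gives 500 ug/mL. Compound 3 `C=C[C@@H]1C[C@]1(NC(=O)[C@@H]1C[C@@H](Oc2nccc3cc(OC)ccc23)CN1C(=O)[C@@H](NC(=O)N[C@H](COC)CC(C)C)C(C)(C)C)C(=O)NS(=O)(=O)C1CC1` gives 225 ug/mL. Compound 2 thus stands second highest of the three numbers: a 2.1-fold lower number from compound 1 to compound 2 (0.33 log units; beyond the scatter), and a 2.2-fold lower number from compound 2 to compound 3 (0.35 log units; beyond the scatter). Taken together, a 4.8-fold lower number from compound 1 to compound 3 (0.68 log units; beyond the scatter).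

Compound 4 `C=C[C@@H]1C[C@]1(NC(=O)[C@@H]1C[C@@H](Oc2nccc3cc(OC)ccc23)CN1C(=O)[C@@H](NC(=O)N[C@H](COC)c1ccccc1)C(C)(C)C)C(=O)NS(=O)(=O)C1CC1` has not yet been measured. Against compound 2 the change is phenyl in place of ethyl on a saturated chain carbon bound to an amide-type nitrogen and a saturated chain carbon. The measured steps each enlarged the group carried on the same urea-linked branch, moving from hydrogen to methyl to isopropyl, and each lowered the number in this assay by a modest amount, beyond the scatter. Phenyl enlarges that branch further still, so a further modest decrease is expected rather than no step at all. Compound 4 is therefore estimated to give 200 ug/mL in this assay, with a likely range from 100 ug/mL to 400 ug/mL. The step this expectation implies is a 2.5-fold lower number from compound 2 to compound 4 (0.40 log units; beyond the scatter).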

Compound 4, solubility: 259 ug/mL
Compound 4: the middle estimate sits 1.3-fold (0.11 log units) below what was measured, within the range that was stated.
By their numbers in this assay, from the lowest: compounds 3, 4 and 2 (each within the scatter of the next, the first and the last beyond it); then compound 1.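

In this assay, putting phenyl on this carbon gives a 1.9-fold lower number from compound 2 to compound 4 (0.29 log units; within the scatter) when ethyl leaves and a 1.2-fold higher number from compound 3 to compound 4 (0.06 log units; within the scatter) when isobutyl leaves, so an aromatic ring of 6 heavy atoms cannot be told apart here from either of these open chains. Only the comparison with the smaller methyl group gives a clear step, a 4.1-fold lower number from compound 1 to compound 4 (0.62 log units; beyond the scatter), which places compound 4 with compound 2 and compound 3 rather than with compound 1. No measurement shown explains why these groups behave alike.

On these data alone, it remains open whether a saturated ring such as cyclohexyl on this carbon would match phenyl. As far as these compounds go, it is also open whether an amine or a carboxylic acid there would bring the number back towards that of compound 1.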